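Hydroxy next to methoxy: a quaternary ammonium indole series

The compounds below may be only part of what the source reports. "The series", "measured", "known", "first", "only" and "open" are said of these compounds alone.

Compound 1, `C[N+](C)(C)Cc1cn(Cc2ccccc2)c2ccccc12`, gives 4200 nM in an assay on HEK293 cells for antagonist activity at Neuronal acetylcholine receptor; alpha4/beta2 (Homo sapiens), read by calcium flux; on this read-out higher numbers stand for weaker inhibition and lower numbers for stronger inhibition.
Compound 2, `C[N+](C)(C)Cc1cn(Cc2cccc(O)c2)c2ccccc12`, gives 14700 nM in this assay.
Compound 3, `COc1ccc(Cn2cc(C[N+](C)(C)C)c3ccccc32)cc1`, gives 4400 nM in this assay.

Compound 3 sits second highest of the three numbers in this assay. Its number and that of compound 1 lie within the scatter of each other, as a 1.0-fold higher number from compound 1 to compound 3 (0.02 log units; within the scatter) shows, while compound 2 gives a number beyond the scatter higher than compound 3.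

The step to compound 4, `COc1ccc(Cn2cc(C[N+](C)(C)C)c3ccccc32)cc1O`, is hydroxy in place of hydrogen on an aromatic carbon. For the measured compounds named here, one measured step bears on it: a 3.5-fold higher number from compound 1 to compound 2 (0.54 log units; beyond the scatter), where a hydroxy group also entered on an aromatic carbon of the same ring, though there without a methoxy group present. That step was modest and beyond the scatter, and it raised the number. Going by the values given here, no measured pair shows a hydroxy entering next to a methoxy, so the expectation rests on that single precedent. Compound 4 is therefore expected to give a modestly higher number than compound 3 in this assay, a step of about a 2.5-fold higher number from compound 3 to compound 4 (0.40 log units; beyond the scatter). The estimate for compound 4 is 11000 nM, with a range from 4500 nM to 27000 nM.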

Compound 4, half-maximal inhibitory concentration: 9500 nM
The estimate for compound 4 lay 1.2-fold (0.06 log units) above the measured number; measured number inside the range.
By their numbers in this assay, from the lowest: compounds 1 and 3 (each within the scatter of the next); then compounds 4 and 2 (each within the scatter of the next).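

With a methoxy group ortho to it, hydroxy in place of hydrogen still raises the number in this assay, a 2.2-fold higher number from compound 3 to compound 4 (0.33 log units; beyond the scatter), so the rise is no longer tied to a single core, and its size agrees with the earlier step: the same change on two cores in this assay, a 3.5-fold higher number (0.54 log units; beyond the scatter) from compound 1 to compound 2 and a 2.2-fold higher number (0.33 log units; beyond the scatter) from compound 3 to compound 4, 1.6-fold (0.21 log units) apart, within the scatter of two such steps. Seen from the other side, methoxy in place of hydrogen leaves the number within the scatter even with the hydroxy group present, a 1.5-fold lower number from compound 2 to compound 4 (0.19 log units; within the scatter), and this matches the step on the core of compound 1: the same change on two cores in this assay, a 1.0-fold higher number (0.02 log units; within the scatter) from compound 1 to compound 3 and a 1.5-fold lower number (0.19 log units; within the scatter) from compound 2 to compound 4, 1.6-fold (0.21 log units) apart, within the scatter of two such steps. Across these four compounds, only the hydroxy step moves the number beyond the scatter, on either core.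

On these data alone, whether an amine or a carboxylic acid at this position would shift the number as hydroxy does remains open. So does the effect of a methoxy group placed here instead of the hydroxy group.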